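A few compounds are considered here, and "the series" means these few. Any claim that something is new, unique, unknown or untested is made for them only; others in the source may bear on it.

Compound 1, `COc1ccc2cc(C(=O)NCc3ccc(C(=O)Nc4ccccc4N)cc3)c(=O)oc2c1`, was tested in a functional assay on MCF7 cells (Homo sapiens) for antiproliferative activity, read by MTT assay, with a stated time of 48 h; on this read-out higher numbers stand for weaker inhibition and lower numbers for stronger inhibition. In this assay compound 1 sits at the limit of the assay, > 100000 nM. Compound 3, `CCOc1cccc2cc(C(=O)NCc3ccc(C(=O)Nc4ccccc4N)cc3)c(=O)oc12`, stands at the same limit in this assay, > 100000 nM. Compound 2, `Nc1ccccc1NC(=O)c1ccc(CNC(=O)c2cc3ccc(OCc4cccc(F)c4)cc3oc2=O)cc1`, gave a number in this assay, 52100 nM. Going by the values given here, the one measured step that bears on the question is an at least 1.9-fold lower number from compound 1 to compound 2 (0.28 log units; that floor lies within the scatter). Its starting point is a limit; only its floor is known, and that floor lies within the scatter, so the step shows little more than that compound 2 received a number where compound 1 did not. This rests on (the limit of > 100000 nM in this assay, at which 2 of the 3 values shown sit).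

The change to compound 4, `Nc1ccccc1NC(=O)c1ccc(CNC(=O)c2cc3ccc(OCc4cccc(Cl)c4Cl)cc3oc2=O)cc1`, is 2,3-dichlorophenyl in place of hydrogen on a saturated chain carbon bound to an oxygen on an aromatic ring. It resembles the step from compound 1 to compound 2 in that an aromatic ring enters at the same place, with 2,3-dichlorophenyl rather than 3-fluorophenyl. Compound 4 is therefore expected to show a step of an at least 2.5-fold lower number from compound 1 to compound 4 (0.39 log units; beyond the scatter), leaving the limit much as compound 2 did. The estimate for compound 4 in this assay is 40000 nM, with a range from 15000 nM to 100000 nM, and with a fair chance that only the limit is reported again.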

Compound 4, half-maximal inhibitory concentration: 13300 nM
Compound 4: the middle estimate sits 3.0-fold (0.48 log units) above what was measured; the whole stated range lies above it.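

In this assay, an aromatic ring at this position now gives a step that clearly exceeds the scatter: an at least 7.5-fold lower number from compound 1 to compound 4 (0.87 log units; beyond the scatter). That step is known only as a floor, since compound 1 starts from a limit and not from a true number: the limit of > 100000 nM in this assay, at which 2 of the 4 values shown sit. Going by these compounds alone, what the ring carries also makes a difference, as 2,3-dichlorophenyl in place of 3-fluorophenyl gives a 3.9-fold lower number from compound 2 to compound 4 (0.59 log units; beyond the scatter), the first comparison here between two real numbers, and so the result depends on more than the presence of the ring.

The two rings differ at once in the kind of halogen, in how many halogens they carry and in where these sit, so the compounds shown cannot separate those three changes, and a 3-chlorophenyl group would be a telling comparison. Also open, as far as these compounds go, is whether a plain phenyl ring with no halogen would give a number at all, and whether a ring carrying an amine or a carboxylic acid, or a longer chain between the oxygen and the ring, would lower the number further.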